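Solubility notes: lactam in place of trifluoromethoxy

A few compounds are considered here, and "the series" means these few. Any claim that something is new, unique, unknown or untested is made for them only; others in the source may bear on it.

Going by the values given here, the two measured members share one core; compound 1 `Cc1noc(-c2nc(C)c3c(c2N)C(=O)N(Cc2ccc(Oc4ccc(F)cc4)cc2)C3=O)n1` carries a 4-fluorophenyl on the oxygen, compound 2 `Cc1noc(-c2nc(C)c3c(c2N)C(=O)N(Cc2ccc(OC(F)(F)F)cc2)C3=O)n1` a trifluoromethyl there. In a physicochemical assay for solubility, using the shake flask method, in simulated intestinal fluid, measured as kinetic solubility, with a stated time of 2 h, at 25 degrees C, at pH 6.5 (on this read-out higher numbers stand for higher solubility and lower numbers for lower solubility), compound 1 gives 23800 nM. For compound 2 this assay reports only a limit, < 5000 nM, so compound 2 stands at the lower edge of what is shown; the single step, an at least 4.7-fold lower number from compound 1 to compound 2 (0.67 log units; beyond the scatter), is the only measured comparison, set against (the limit of < 5000 nM in this assay, at which 1 of the 2 values shown sits).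

Compound 3 `Cc1noc(-c2nc(C)c3c(c2N)C(=O)N(Cc2ccc(N4CCCC4=O)cc2)C3=O)n1` differs from compound 2 by 2-oxopyrrolidin-1-yl in place of trifluoromethoxy on an aromatic carbon. Among the compounds with values here, no measured step covers this change; the one step above concerns a different group at the same position and offers no direct guide. The expectation is a return toward the number seen for compound 1, estimated as an at least 4.0-fold higher number from compound 2 to compound 3 (0.60 log units; beyond the scatter). Compound 3 is accordingly expected to reach 20000 nM, within 5000 nM to 80000 nM.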

Compound 3, solubility: < 5000 nM
Compound 3: a limit, no number; the forecaster's own chance of this, stated with the estimate: 25%; at least 4.0-fold (0.60 log units) between middle value and limit.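

In this assay compound 3 gives < 5000 nM, which is a limit and not a number. Placing 2-oxopyrrolidin-1-yl in place of 4-fluorophenoxy on this aromatic carbon gives an at least 4.7-fold lower number from compound 1 to compound 3 (0.67 log units; beyond the scatter), so a second, ring-bearing group at this position also falls short of the 4-fluorophenoxy result. The step between the trifluoromethoxy and 2-oxopyrrolidin-1-yl groups cannot be read, since both values are limits: the limit of < 5000 nM in this assay, at which 2 of the 3 values shown sit.

Where compound 2 and compound 3 lie under that limit remains open, and with it whether these two groups differ at all. Also open, on these data alone, is whether a tertiary amine, a carboxylic acid or an open-chain amide on this aromatic carbon would give a readable number closer to that of compound 1.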